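Hydroxy added to the aryl of compound 1

A few compounds are considered here, and "the series" means these few. Any claim that something is new, unique, unknown or untested is made for them only; others in the source may bear on it.

Among the compounds with values here, compound 1 `Oc1ccc(C2CC(c3ccccc3O)=NN2c2cccc(Cl)c2)cc1F` gives 2900 nM in an assay on isolated protein for inhibition of protein kinase C zeta type (Homo sapiens), with a stated time of 4 min (a higher number here means a weaker inhibitor, a lower number a stronger inhibitor), the lowest of the three numbers so far. Compound 2 `Oc1ccccc1C1=NN(c2cccc(Cl)c2)C(c2cc(F)c(O)c(F)c2)C1` gives 11100 nM and compound 3 `Oc1ccccc1C1=NN(c2cccc(Cl)c2)C(c2ccc(O)c(F)c2F)C1` gives 6600 nM. Both measured steps from compound 1 put fluoro in place of hydrogen on an aromatic carbon: a 3.8-fold higher number from compound 1 to compound 2 (0.58 log units; beyond the scatter) and a 2.3-fold higher number from compound 1 to compound 3 (0.36 log units; beyond the scatter), each modest, while the step of a 1.7-fold lower number from compound 2 to compound 3 (0.23 log units; within the scatter) stays within the scatter. Compound 4 `Oc1ccc(C2=NN(c3cccc(Cl)c3)C(c3ccc(O)c(F)c3)C2)c(O)c1` differs from compound 1 by hydroxy in place of hydrogen on an aromatic carbon, which reads 2-hydroxyphenyl to 2,4-dihydroxyphenyl. Within the data shown here, no measured step touches this ring; the fluoro steps show only that a substitution elsewhere on compound 1 moved this assay modestly. For compound 4 the expected step is therefore a 1.2-fold higher number from compound 1 to compound 4 (0.08 log units; within the scatter), modest or none beyond the scatter, estimated at 3500 nM within 1500 nM to 8000 nM.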

Compound 4, half-maximal inhibitory concentration: < 100 nM
Compound 4 gave a limit, no number; the forecaster's own chance of this, stated with the estimate: 5%; middle value at least 35-fold (1.54 log units) away from the limit.
By their numbers in this assay, from the lowest: compound 1; then compounds 3 and 2 (each within the scatter of the next). At a limit, below all of these: compound 4.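

A new hydroxy on the 2-hydroxyphenyl, para to a large group and meta to a hydroxy group, gives an at least 29-fold lower number from compound 1 to compound 4 (1.46 log units; beyond the scatter) in this assay. This ring, untouched by the fluoro steps, moves the number far more than those steps did. The result for compound 4 is a limit and not a number: the limit of < 100 nM in this assay, at which 1 of the 4 values shown sits.

Open, going by these compounds, is whether a methoxy, an amine or a carboxylic acid at this place would do the same as hydroxy. Also open, on these data alone, is how the fluoro patterns of compound 2 and compound 3 read on the 2,4-dihydroxyphenyl.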